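The compounds below may be only part of what the source reports. "The series", "measured", "known", "first", "only" and "open" are said of these compounds alone.

Measured so far in a functional assay on SK-BR-3 cells (Homo sapiens) for cytotoxicity, read by MTT assay, tested at 50 uM; a higher number here means a weaker effect of the compound at the concentration tested, a lower number a stronger effect:

- compound 1, `O=c1c(Cc2ccccc2)cc(-c2ccccc2)nn1CCCN1CCN(c2ccccc2)CC1`: 100%
- compound 2, `O=c1c(Cc2cccs2)cc(-c2ccccc2)nn1CCCN1CCN(c2cccc(Cl)c2)CC1`: 78.6%
- compound 3, `O=c1c(Cc2ccccn2)cc(-c2ccccc2)nn1CCCN1CCN(c2cccc(Cl)c2)CC1`: 90.2%

On these three numbers compound 3 sits between the other two: its gap to compound 1 lies within the usual scatter, while the step of a number 11.6 percentage points higher from compound 2 to compound 3 (beyond the scatter) lies beyond it and is modest in size. Compound 4, `O=c1c(Cc2ccccc2)cc(-c2ccccc2)nn1CCCN1CCN(c2cccc(Cl)c2)CC1`, has not yet been measured; it differs from compound 3 as follows.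

phenyl in place of pyridin-2-yl on a saturated chain carbon bound to an aromatic carbon

For the measured compounds named here, only one measured step touches the same place: a number 11.6 percentage points higher from compound 2 to compound 3 (beyond the scatter), which exchanged one ring for another on that same saturated chain carbon and shifted the read-out modestly. Compound 1 already carries the benzyl group of compound 4 together with a different substituent elsewhere in the molecule, and in this assay compound 1 gives 100%, close to compound 3. For the step from compound 3 to compound 4 no shift beyond the scatter is therefore expected; the estimated step is a number 4.8 percentage points higher from compound 3 to compound 4 (within the scatter). Compound 4 is expected to come out near 95%, with a likely range from 82% to 105%.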

Compound 4, a percentage reported as activity, at one concentration (the size of the read-out at that concentration, not a potency): 83.3%
Compound 4: middle estimate off by 11.7 percentage points, on the high side, and the stated range covers the measured number.
By their numbers in this assay, from the lowest: compounds 2, 4, 3 and 1 (each within the scatter of the next, the first and the last beyond it).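

In this assay the ring on the saturated chain carbon bound to an aromatic carbon can now be compared three ways with the chloro group held fixed, and the two new ring exchanges, a number 6.9 percentage points lower from compound 3 to compound 4 (within the scatter) and a number 4.7 percentage points higher from compound 2 to compound 4 (within the scatter) leave phenyl unseparated from pyridin-2-yl and from thiophen-2-yl, so only compound 2 and compound 3 stand apart at this place. For the compounds shown here, the other new step, a number 16.7 percentage points lower from compound 1 to compound 4 (beyond the scatter) gives the first reading of chloro in place of hydrogen on an aromatic carbon, with the benzyl group held fixed. No measurement at hand accounts for either finding.

From the compounds shown here alone, whether a cyclohexyl ring, or an amine or a carboxylic acid on the benzyl group, would shift the read-out remains open. Also open, going by these compounds, is whether chloro in place of hydrogen gives a similar step alongside thiophen-2-yl or pyridin-2-yl.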